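A few compounds are considered here, and "the series" means these few. Any claim that something is new, unique, unknown or untested is made for them only; others in the source may bear on it.

In a functional assay on MV4-11 cells (Homo sapiens) for antiproliferative activity, read by CCK-8 assay, with a stated time of 72 h (on this read-out higher numbers stand for weaker inhibition and lower numbers for stronger inhibition), compound 3 `Cn1cc(-c2ccccc2Oc2ccccc2)c2cc(C(=O)NCCCCC(=O)NO)[nH]c2c1=O` gives 180 nM, the middle of three numbers: compound 1 `Cn1cc(-c2ccccc2Oc2ccccc2)c2cc(C(=O)NCCCCCC(=O)NO)[nH]c2c1=O` reads 610 nM and compound 2 `Cn1cc(-c2ccccc2Oc2ccccc2)c2cc(C(=O)NCCCCCC(=O)Nc3ccccc3N)[nH]c2c1=O` reads 70 nM. Compound 4 `Cn1cc(-c2ccccc2Oc2ccccc2)c2cc(C(=O)NCCCCCCC(=O)Nc3ccccc3N)[nH]c2c1=O` differs from compound 3 as follows: 2-((2-aminophenyl)carbamoyl)ethyl in place of hydroxycarbamoyl on a saturated chain carbon, four bonds along the chain from an amide-type nitrogen. Two measured changes bear on this and point in opposite directions. Placing 2-aminophenyl in place of hydroxy gave an 8.7-fold lower number from compound 1 to compound 2 (0.94 log units; beyond the scatter), and the shorter chain gave a 3.4-fold lower number from compound 1 to compound 3 (0.53 log units; beyond the scatter), while compound 4 has a longer chain than compound 3. The combined change gave a 2.6-fold higher number from compound 2 to compound 3 (0.41 log units; beyond the scatter). The gain from the 2-aminophenyl group and the loss from the longer chain should roughly cancel, so no shift beyond the scatter is expected in this assay. The estimated outcome is a 1.2-fold lower number from compound 3 to compound 4 (0.08 log units; within the scatter). For compound 4 the expected value is 150 nM, with an estimated range of 50 nM to 450 nM.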

Compound 4, half-maximal inhibitory concentration: 130 nM
Beside the measured number, compound 4's estimate is 1.2-fold (0.06 log units) above it; the measured number falls inside the stated range.
By their numbers in this assay, from the lowest: compounds 2, 4 and 3 (each within the scatter of the next, the first and the last beyond it); then compound 1.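

In this assay, the longer chain on the 2-aminophenyl amide stays within the scatter, with a 1.9-fold higher number from compound 2 to compound 4 (0.27 log units; within the scatter), whereas shortening the chain on the hydroxycarbamoyl end gave a 3.4-fold lower number from compound 1 to compound 3 (0.53 log units; beyond the scatter). The longest-chain 2-aminophenyl amide separates from one hydroxycarbamoyl compound, with a 4.7-fold lower number from compound 1 to compound 4 (0.67 log units; beyond the scatter), but not from the other, with a 1.4-fold lower number from compound 3 to compound 4 (0.14 log units; within the scatter). Going from a (2-aminophenyl)carbamoyl end to a hydroxycarbamoyl end on a shorter chain reads alike in two pairs: the same change on two cores in this assay, a 2.6-fold higher number (0.41 log units; beyond the scatter) from compound 2 to compound 3 and a 4.7-fold higher number (0.67 log units; beyond the scatter) from compound 4 to compound 1, 1.8-fold (0.26 log units) apart, within the scatter of two such steps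

Still open, as far as these compounds go, is whether a yet longer chain on the 2-aminophenyl amide holds this level. Also open, from the compounds shown here alone, is how a carboxylic acid end group would read at this position.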